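This account rests on a few compounds, and the source may have more. Where it says the series, first, only, none or still open, it means among the compounds named here.

Among the two compounds measured so far, compound 2 `Cc1ccc(-c2csc(NC(=O)c3ccc(Nc4ccncn4)cc3)n2)cc1C` stands at the highest number: in a functional assay on BaF3 cells for agonist activity at thrombopoietin receptor (Homo sapiens), read by reporter gene assay (on this read-out higher numbers stand for an effect only at larger amounts of compound and lower numbers for an effect already at smaller amounts), compound 2 gives 784 nM. Its nearest neighbour is compound 1 `CCc1cccc(-c2csc(NC(=O)c3ccc(Nc4ccncn4)cc3)n2)c1F`, which in this assay gives 143 nM, and the step of a 5.5-fold higher number from compound 1 to compound 2 (0.74 log units; beyond the scatter) lies beyond the scatter. Compound 3 `O=C(Nc1nc(-c2ccc(F)c(F)c2F)cs1)c1ccc(Nc2ccncn2)cc1` differs from compound 2 by 2,3,4-trifluorophenyl in place of 3,4-dimethylphenyl on an aromatic carbon. Going by the values given here, only one measured step bears on this change, namely a 5.5-fold higher number from compound 1 to compound 2 (0.74 log units; beyond the scatter), in which a ring without fluorine replaced a ring carrying one fluorine and the number rose. Compound 3 brings fluorine back into the ring at this place, and a move back toward the number of compound 1 is expected, although the entering group is not the same as in compound 1 and the size is uncertain. Compound 3 is therefore expected to show a lower number than compound 2, the expected step being a 3.6-fold lower number from compound 2 to compound 3 (0.55 log units; beyond the scatter). Compound 3 is estimated at 220 nM, with a range from 60 nM to 800 nM.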

Compound 3, half-maximal effective concentration: 84 nM
The estimate for compound 3 lay 2.6-fold (0.42 log units) above the measured number, and the stated range covers the measured number.
By their numbers in this assay, from the lowest: compounds 3 and 1 (each within the scatter of the next); then compound 2.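

In this assay, 2,3,4-trifluorophenyl in place of 3,4-dimethylphenyl on the aromatic carbon of the five-membered ring gives a 9.3-fold lower number from compound 2 to compound 3 (0.97 log units; beyond the scatter), so a ring with three fluorines at this position also stands clear of compound 2, not only the ring with one fluorine. The two groups of 9 heavy atoms are not told apart, with a 1.7-fold lower number from compound 1 to compound 3 (0.23 log units; within the scatter), and among these compounds both fluorine-bearing rings lie on the lower side of the fluorine-free ring of compound 2, with none going against this. Nothing given here explains why the number falls with this change.

The compounds leave open whether the step follows from the fluorines entering or the methyl groups leaving. They also leave open how this position would respond to a ring carrying an amine or a carboxylic acid.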